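The compounds below may be only part of what the source reports. "The series", "measured", "known", "first", "only" and "open" are said of these compounds alone.

For the measured compounds named here, in an in vivo ADME assay on the whole organism for pharmacokinetics, with Rattus norvegicus as the target, at a dose of 5 mg/kg (on this read-out lower numbers stand for slow clearance and higher numbers for fast clearance), compound 1 `CC[C@H](C)[C@@H]1C(=O)N[C@H](C2Cc3ccccc3C2)C(=O)N1[C@@H](C(=O)N1CCOCC1)c1ccc(C)nc1` gives 27 mL/min/kg and compound 2 `CC[C@@H](C)[C@@H]1C(=O)N[C@H](C2Cc3ccccc3C2)C(=O)N1[C@@H](C(=O)N1CCOCC1)c1ccc(C)nc1` gives 39 mL/min/kg; the one measured step, a 1.4-fold higher number from compound 1 to compound 2 (0.16 log units; within the scatter), goes with the fact that compounds 1 and 2 differ only in the configuration as drawn and nothing else. Compound 3 `COc1ccc([C@H](C(=O)N(C)C)N2C(=O)[C@@H](C3Cc4ccccc4C3)NC(=O)[C@H]2CC(C)C)cn1` gives 23 mL/min/kg in this assay, standing at the low end of the three numbers, with compound 1 nearest and compound 2 furthest, both within the scatter of it. Compound 4 `Cc1ccc([C@H](C(=O)N(C)C)N2C(=O)[C@@H](C3Cc4ccccc4C3)NC(=O)[C@H]2CC(C)C)cn1` differs from compound 3 by methyl in place of methoxy on an aromatic carbon. Going by the values given here, no measured step covers a methyl in place of methoxy; the configuration-only step between compound 1 and compound 2 does not bear on it, so in this assay no movement beyond the scatter is expected. Compound 4 is therefore estimated at 25 mL/min/kg, range 12 mL/min/kg to 50 mL/min/kg, an expected step of a 1.1-fold higher number from compound 3 to compound 4 (0.04 log units; within the scatter).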

Compound 4, clearance: 18 mL/min/kg
For compound 4 the middle estimate is 1.4-fold (0.14 log units) above the measured one, within the range that was stated.
By their numbers in this assay, from the lowest: compounds 4, 3, 1 and 2 (each within the scatter of the next, the first and the last beyond it).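

In this assay, methyl in place of methoxy on the aromatic carbon next to the ring nitrogen gives a 1.3-fold lower number from compound 3 to compound 4 (0.11 log units; within the scatter) and so lies within the scatter. On this read-out, 6-methoxypyridin-3-yl and 6-methylpyridin-3-yl are therefore not told apart on the core shared by compounds 3 and 4. Nothing at hand bears on a cause for this step.

From the compounds shown here alone, how an amine, a carboxylic acid or a longer chain such as ethoxy would read at this position remains open. Going by these compounds, whether the same change reads alike on another core also remains open.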